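A smaller group on compound 1: the step to compound 3

This account rests on a few compounds, and the source may have more. Where it says the series, first, only, none or still open, it means among the compounds named here.

Measured so far in a physicochemical assay for lipophilicity, using the shake flask method, at pH 7.4; on this read-out higher numbers stand for higher lipophilicity and lower numbers for lower lipophilicity:
- Compound 1 (`CCCC(Oc1ccc(-n2cc3ccccc3n2)cc1)c1ccc(C(=O)NCCC(=O)O)cc1`): (2.5)
- Compound 2 (`O=C(O)CCNC(=O)c1ccc(C(Oc2ccc(-n3cc(C(F)(F)F)cn3)cc2)C2CCC2)cc1`): (2.6)

These two compounds lie within the usual scatter of each other, so compound 1 does not stand apart from compound 2 on these numbers. Among the compounds with values here, they also differ in more than one place, and no measured pair shows the effect of a single change.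

The account now follows the step to compound 3 (`CCCC(Oc1ccc(-n2cc(F)cn2)cc1)c1ccc(C(=O)NCCC(=O)O)cc1`), which has not yet been measured. The change from compound 1 is this: 4-fluoro-1H-pyrazol-1-yl in place of 2H-indazol-2-yl on an aromatic carbon. In words, 4-fluoro-1H-pyrazol-1-yl comes in place of 2H-indazol-2-yl on an aromatic carbon, para to a large group, and the rest of the structure stays as it is.

Within the data shown here, with no measured step to draw on, the expectation rests on this change alone, starting from compound 1 (2.5), with fewer heavy atoms entering than leaving. A lower number is expected, an estimated step (a number 0.60 log units lower from compound 1 to compound 3 (beyond the scatter)) that would lie beyond the usual scatter. For compound 3 the estimated value is 1.9 (expected range 1.5 to 2.3).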

Compound 3, distribution coefficient: 2
Compound 3: the middle estimate sits 0.10 log units below what was measured, within the range that was stated.
By their numbers in this assay, from the lowest: compound 3; then compounds 1 and 2 (each within the scatter of the next).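

In this assay, the replacement of 2H-indazol-2-yl by 4-fluoro-1H-pyrazol-1-yl on an aromatic carbon, para to a large group, gives the only single-place step among the compounds shown: a number 0.50 log units lower from compound 1 to compound 3 (beyond the scatter). This shows that the read-out responds to the group at this position, even though the entering and leaving groups have the same counted hydrogen-bond donors and acceptors and neither carries a net charge; what differs in the counts is 6 heavy atoms entering against 9 leaving, one aromatic ring rather than two, and the fluorine. No measurement shown accounts for the step, and it cannot be divided between the loss of the six-membered aromatic ring and the arrival of the fluorine.

The compounds shown leave open what an unsubstituted pyrazole ring would give here, and whether a chlorine atom, a methyl group or an amine in place of the fluorine would move the number in this assay. They also leave open whether the same exchange would give a step of similar size if the chain of compound 1 were replaced by a longer chain.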